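Swapping Chloro for Dimethylamino at the Far Ring

A few compounds are considered here, and "the series" means these few. Any claim that something is new, unique, unknown or untested is made for them only; others in the source may bear on it.

In a functional assay on DU-145 cells (Homo sapiens) for inhibition, read by trypan blue exclusion, with a stated time of 96 h (a lower number here means a stronger inhibitor of growth, a higher number a weaker inhibitor of growth), compound 2 `O=C(/C(=C\c1ccc(Cl)cc1)SCc1ccc(Cl)cc1)c1ccc(Br)cc1` gives 10000 nM. Compound 1 `Cc1ccc(S/C(=C/c2ccc(Cl)cc2)C(=O)c2ccc(Br)cc2)cc1` gives 10000 nM, and compound 3 `O=C(/C(=C\c1ccc(Cl)cc1)SCc1ccc(Cl)cc1)c1ccccc1Cl` gives 30000 nM; the step of no change at the digits printed from compound 1 to compound 2 (within the scatter) is within the scatter, while the step of a 3.0-fold higher number from compound 2 to compound 3 (0.48 log units; beyond the scatter) is a modest loss, so compound 2 stands level with compound 1 and together they hold the lowest numbers of the three. Compound 4 `CN(C)c1ccc(/C=C(/SCc2ccc(Cl)cc2)C(=O)c2ccc(Br)cc2)cc1` differs from compound 2 by dimethylamino in place of chloro on an aromatic carbon. Neither measured step touches that position: one alters the group on the sulfur, the other the aryl on the carbonyl carbon, and the larger of them was only modest. Compound 4 is therefore expected to show no change at the digits printed from compound 2 to compound 4 (within the scatter), at about 10000 nM with a range of 3000 nM to 30000 nM.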

Compound 4, concentration for 50% growth inhibition: 10000 nM
Estimate against measurement, compound 4: no gap at the digits printed; low and high end bracket the measured number.
By their numbers in this assay, from the lowest: compounds 1, 2 and 4 (each within the scatter of the next); then compound 3.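

In this assay, dimethylamino in place of chloro on this aromatic carbon, para to a large group, gives no change at the digits printed from compound 2 to compound 4 (within the scatter) even though three heavy atoms replace one and a hydrogen-bond acceptor enters. This is the first change shown at this position, and compound 4 stands with compounds 1 and 2 among the lowest numbers of the four. Nothing available explains this outcome. Going by these compounds, whether a carboxylic acid or a methoxy group here would shift the number remains open. On these data alone, it is also open whether dimethylamino would give the same result with 2-chlorophenyl on the carbonyl carbon.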